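Aryl urea aziridine nitriles: a sulfamoyl replacement

The source may hold more compounds than are shown below. What is called first, only, known or untested is meant among the compounds shown, and "the series" means these compounds.

Compound 1, `N#CC1CN1C(=O)Nc1ccc([N+](=O)[O-])cc1`, gives 9100 nM in a functional assay on RPMI-8226 cells (Homo sapiens) for inhibition; a higher number here means a weaker inhibitor, a lower number a stronger inhibitor. Compound 2, `N#CC1CN1C(=O)Nc1ccc(C(F)(F)F)cc1`, gives 8200 nM in this assay.

Only these two numbers exist so far, and compound 2 and compound 1 lie within the scatter of each other: the change a 1.1-fold lower number from compound 1 to compound 2 (0.05 log units; within the scatter) is too small to count as a difference. Both compounds share the same core, and differ only in the group on the aromatic carbon that carries the nitro in compound 1 and the trifluoromethyl in compound 2.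

Compound 3, `N#CC1CN1C(=O)Nc1ccc(S(N)(=O)=O)cc1`, has not yet been measured. It differs from compound 2 by sulfamoyl in place of trifluoromethyl on an aromatic carbon. Among the measured compounds shown here, the one step that bears on it, from nitro to trifluoromethyl, was a 1.1-fold lower number from compound 1 to compound 2 (0.05 log units; within the scatter), and it left this assay unchanged within the scatter, so a swap of the group at this same place is expected to move the number little, in neither direction beyond the scatter. On this basis compound 3 is estimated at 9000 nM, within 3000 nM to 30000 nM. The expected step from compound 2 is a 1.1-fold higher number from compound 2 to compound 3 (0.04 log units; within the scatter).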

Compound 3, half-maximal inhibitory concentration: > 38000 nM
Compound 3: no number, only a limit; the forecaster's own chance of this, stated with the estimate: 20%; at least 4.2-fold (0.62 log units) between middle value and limit.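

Compound 3 carries no number in this assay, only a limit: the limit of > 38000 nM in this assay, at which 1 of the 3 values shown sits.

This shows that the group at this place is not interchangeable, as the step between the first two compounds, a 1.1-fold lower number from compound 1 to compound 2 (0.05 log units; within the scatter), had left possible: sulfamoyl gives an at least 4.6-fold higher number from compound 2 to compound 3 (0.66 log units; beyond the scatter), and against nitro it gives an at least 4.1-fold higher number from compound 1 to compound 3 (0.62 log units; beyond the scatter). The true size of both steps remains unknown, since each is bounded on one side only, but both lie beyond the scatter, so the place on the aromatic carbon para to a group of 8 heavy atoms responds to what it carries, and sulfamoyl is the one change among these three compounds that costs inhibition in this assay.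

The compounds shown do not separate which feature of sulfamoyl matters, for instance whether the free hydrogens on its nitrogen count, which a methylsulfonyl group or a dimethylsulfamoyl group at the same place would address. They also leave open how an amine or a carboxylic acid at this place would fall relative to nitro and trifluoromethyl, and whether any group here brings the number lower than the first two compounds.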